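The source may report more compounds than this note shows. Statements on the series, on what has been measured and on what is new or still open speak of the compounds shown alone.

Measured so far in a functional assay on A549 cells (Homo sapiens) for cytotoxicity, read by MTT assay; a higher number here means a weaker inhibitor, a lower number a stronger inhibitor:

Compound 1 `C/C1=C/C2=C(CC(C)(C)[C@H]2O)[C@H](C)CC[C@@H]1O`: > 10 ug/mL (a limit)
Compound 2 `C/C1=C/C2=CC(C)(C)C[C@@]2(OO)[C@H](C)CC[C@@H]1O`: > 10 ug/mL (a limit)

Neither compound has a numerical half-maximal inhibitory concentration in this assay. The whole record is the limit of > 10 ug/mL in this assay, at which 2 of the 2 values shown sit. Compound 2 therefore stands at the limit of the assay, and its true position is not known. Within the data shown here, no step between measured compounds is available to serve as a guide.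

The next compound, compound 3 `C/C1=C/C2=CC(C)(C)C[C@]2(OO)[C@H](C)CC[C@@H]1O`, has the same atoms and bonds as compound 2. The only difference is the two compounds have the same atoms and bonds and differ only in configuration as drawn: 1 of 4 stereo elements differ; a stereocentre at a saturated ring carbon is drawn R in compound 2 and S in compound 3: a stereocentre at a saturated ring carbon is drawn R in compound 2 and S in compound 3. The data do not show what a change of this kind does in this assay, so no direction is favoured. The expected step that the limit leaves unreadable from compound 2 to compound 3 is estimated to lie within the usual scatter. Compound 3 will most likely be reported as a limit again, with no number. If a number is obtained, compound 3 is expected to give about 13 ug/mL, within an estimated range of 5 ug/mL to 30 ug/mL.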

Compound 3, half-maximal inhibitory concentration: > 10 ug/mL
Compound 3: a limit, no number; the forecaster's own chance of this, stated with the estimate: 75%; the middle value lies beyond the limit too.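

Compound 3 gives > 10 ug/mL in this assay, which is a limit and not a number, so no step from compound 2 can be read: the limit of > 10 ug/mL in this assay, at which 3 of the 3 values shown sit.

The compounds shown leave open whether the configuration at the saturated ring carbon matters in this assay, and where compound 2 and compound 3 truly stand.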